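Hydrazone series: aryl swap from compound 3 to compound 4

The source may hold more compounds than are shown below. What is called first, only, known or untested is meant among the compounds shown, and "the series" means these compounds.

Working notes on a set of hydrazones built on one shared core. Compound 1 `CC1CCC(=NNc2ccccc2C(=O)O)c2ncc(C(=O)O)c(=O)n21` carries a carboxylic acid on its aryl group; in a functional assay on the whole organism with Rattus norvegicus as the target (a lower number here means that less compound is needed, a higher number that more compound is needed for the effect), compound 1 gives only a limit, > 100 umol/kg. For the measured compounds named here, compound 2 `Cc1cc(C)c(NN=C2CCC(C)n3c2ncc(C(=O)O)c3=O)cc1C`, with a trimethylphenyl group, is the one member of the set with a number, and in this assay compound 2 gives 320 umol/kg. Compound 3 `CC1CCC(=NNc2ccc(Cl)cc2Cl)c2ncc(C(=O)O)c(=O)n21`, with a 2,4-dichlorophenyl group, again stops at a limit: in this assay compound 3 gives > 100 umol/kg. Compound 3 therefore stands at the limit, and among the three values shown two sit there (the limit of > 100 umol/kg in this assay, at which 2 of the 3 values shown sit); only compound 2 carries a number, which lies not far from that limit.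

Compound 4 `CC1CCC(=NNc2cc(Cl)ccc2O)c2ncc(C(=O)O)c(=O)n21` is not yet measured. The change (5-chloro-2-hydroxyphenyl in place of 2,4-dichlorophenyl on an amine nitrogen).

Going by the values given here, no measured step connects two members of the set, so the size of this step cannot be anchored. Given that compound 3 gives > 100 umol/kg and the set otherwise offers only compound 2 at 320 umol/kg, the step that the limit leaves unreadable from compound 3 to compound 4 is expected to be small, in either direction, and within the scatter. Compound 4 is estimated at 250 umol/kg in this assay, with a range from 80 umol/kg to 800 umol/kg, and a limit is the more likely report.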

Compound 4, dose for 50% inhibition: > 100 umol/kg
Compound 4: no number, only a limit; the forecaster's own chance of this, stated with the estimate: 65%; the middle value lies beyond the limit too.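

For the compounds shown here, compound 3 and compound 4 both give only a limit in this assay, so no step between them can be read: the limit of > 100 umol/kg in this assay, at which 3 of the 4 values shown sit. The compounds shown leave open whether 5-chloro-2-hydroxyphenyl in place of 2,4-dichlorophenyl on an amine nitrogen changes the dose needed at all, and by how much.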